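A Methyl Added on the Sulfonyl Ring of Compound 2

The compounds below may be only part of what the source reports. "The series", "measured", "known", "first", "only" and "open" are said of these compounds alone.

Two compounds carry entries in an assay on HEK293 cells for displacement of a labelled ligand from Type-2 angiotensin II receptor (Homo sapiens); on this read-out higher numbers stand for weaker inhibition and lower numbers for stronger inhibition:
compound 1, `CCCCNC(=O)[C@@H](NC(=O)c1cccc(Cn2ccnc2)c1)[C@@H](C)CC`, with "not determined" (no result reported);
compound 2, `CC[C@H](C)[C@H](NC(=O)c1cccc(Cn2ccnc2)c1)C(=O)NNS(=O)(=O)c1ccccc1`, with > 100000 nM.

Compound 1 thus contributes no result. For compound 2 the entry > 100000 nM is a limit of this assay rather than a number. Where compound 2 stands among these values is therefore only a bound: the limit of > 100000 nM in this assay, at which 1 of the 2 values shown sits. Compound 3, `CC[C@H](C)[C@H](NC(=O)c1cccc(Cn2ccnc2)c1)C(=O)NNS(=O)(=O)c1ccc(C)cc1`, differs from compound 2 in one place, (methyl in place of hydrogen on an aromatic carbon). Within the data shown here, no step between measured compounds exists here to set the size of such a change in this assay, and the single measured value is a limit. The expected step from compound 2 to compound 3 is a step that the limit leaves unreadable from compound 2 to compound 3, that is, none beyond the scatter of repeated measurements. Compound 3 is accordingly expected to give 150000 nM in this assay, with a range from 30000 nM to 1000000 nM, and most likely again only a limit.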

Compound 3, inhibition constant: 29000 nM
Estimate against measurement, compound 3: 5.2-fold (0.71 log units) above; measured number below the stated range.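

In this assay, the methyl on the aromatic carbon, para to a large group, gives an at least 3.4-fold lower number from compound 2 to compound 3 (0.53 log units; beyond the scatter), so this place on the phenylsulfonyl ring responds to the addition of a single carbon. Compound 3 also provides the only single number among the compounds shown, 29000 nM, giving the series a measured point where the earlier entries gave none. The true size of the step stays unknown because compound 2 carries only a limit of the assay: the limit of > 100000 nM in this assay, at which 1 of the 3 values shown sits.

From the compounds shown here alone, whether an ethyl group, a methoxy group or a chlorine atom on the same carbon would lower the number further, or raise it again, remains open. Among these compounds, the entry for compound 1, "not determined" (no result reported), allows no step to be read, so the other end of the molecule stays unexplored in this assay.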